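This account rests on a few compounds, and the source may have more. Where it says the series, first, only, none or still open, it means among the compounds named here.

Working notes on the series sharing the core of compound 1.

Three compounds have been run in a functional assay on PANC-1 cells (Homo sapiens) for cytotoxicity, read by MTT assay, with a stated time of 72 h; on this read-out lower numbers stand for stronger inhibition and higher numbers for weaker inhibition. Compound 1, `CCc1ccc(-c2ccc(NC3=CC(=O)c4ncncc4C3=O)cc2)cc1`, gives 1200 nM. Compound 2, `COc1ccc(NC2=CC(=O)c3ncncc3C2=O)cc1OC`, gives 900 nM; its number and that of compound 1 lie within the scatter of each other, so nothing separates them. Compound 3, `O=C1C(Nc2cccc(B(O)O)c2)=CC(=O)c2ncncc21`, gives 9000 nM, a number that stands above compound 1 by more than the scatter. On the numbers shown, compound 1 therefore sits second highest of the three, close to compound 2 and well below compound 3.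

The next compound, compound 4, `NS(=O)(=O)c1ccc(NC2=CC(=O)c3ncncc3C2=O)cc1`, has not yet been measured in this assay. Against compound 1 the change is sulfamoyl in place of 4-ethylphenyl on an aromatic carbon. Going by the values given here, no pair of measured compounds in this set differs in one place only, so there is no measured step to lean on, and the two remaining compounds give no bearing on a sulfamoyl group at this place.

The expectation for compound 4 is a weaker result than compound 1, with the step of a 3.3-fold higher number from compound 1 to compound 4 (0.52 log units; beyond the scatter) expected to exceed the scatter; this leans on compound 3, which gives 9000 nM with a small, donor-bearing group in place of the larger aryl groups of compound 1 and compound 2. Compound 4 is estimated at 4000 nM, within 1200 nM to 14000 nM.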

Compound 4, half-maximal inhibitory concentration: > 10000 nM
Compound 4: no number, only a limit (the forecaster's own chance of this, stated with the estimate: 10%); middle value at least 2.5-fold (0.39 log units) from the limit.
By their numbers in this assay, from the lowest: compounds 2 and 1 (each within the scatter of the next); then compound 3. At a limit, above all of these: compound 4.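

In this assay compound 4 reads > 10000 nM, which is a limit of the assay and not a number: the limit of > 10000 nM in this assay, at which 1 of the 4 values shown sits. Sulfamoyl in place of 4-ethylphenyl on an aromatic carbon, para to a large group, is the first change in this series that can be read in one place, and it gives an at least 8.3-fold higher number from compound 1 to compound 4 (0.92 log units; beyond the scatter). On these data alone, this position is therefore not indifferent to what it carries, although the full size of the loss stays unknown, and the ring, the heavy-atom count and the donors and acceptors all change together in this single step, so it cannot tell which of them carries the loss.

The compounds shown leave open whether a phenyl ring without the ethyl chain would keep the number of compound 1 at this place, which would show how much of the 4-ethylphenyl group is needed. They also leave open whether an amine or a carboxylic acid at this place would fall off as compound 4 does, or whether the loss is particular to sulfamoyl.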